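A few compounds are considered here, and "the series" means these few. Any claim that something is new, unique, unknown or untested is made for them only; others in the source may bear on it.

compound 1 `Cc1nn(-c2ccccc2)c2nc(-c3ccccc3)c(C#N)c(-c3ccccc3O)c12` gives > 23000 nM (a limit)
compound 2 `CCc1ccc(-c2nc3c(c(C)nn3-c3ccccc3)c(-c3ccccc3Cl)c2C#N)cc1` gives > 20000 nM (a limit)

In an ADME assay on BJ cells (Homo sapiens) for cytotoxicity, with a stated time of 72 h (on this read-out higher numbers stand for an effect only at larger amounts of compound and lower numbers for an effect already at smaller amounts), compound 2 gives > 20000 nM as a limit of the assay, not a number. Compound 1 gives > 23000 nM as a limit too. Going by the values given here, neither compound therefore offers an exact value, and no measured step shows what a change of group does here.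

Compound 3 `CCc1ccc(-c2nc3c(c(C)nn3-c3ccccc3)c(-c3ccccc3OC(F)(F)F)c2C#N)cc1` has trifluoromethoxy in place of chloro on an aromatic carbon, ortho to a large group trifluoromethoxy in place of chloro on an aromatic carbon and otherwise matches compound 2.

The expected step in this assay is a number no higher from compound 2 to compound 3 (the limit leaves the size open) and is expected to stay within the scatter, in neither direction. This expectation rests on compound 2 and its limit of > 20000 nM as the closest reference. For compound 3 the estimated value is 20000 nM with an expected range from 8000 nM to 30000 nM and quite possibly only a limit again.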

Compound 3, half-maximal effective concentration: > 20000 nM
Compound 3: only a limit was reported; the forecaster's own chance of this, stated with the estimate: 75%; the middle value sits exactly at the limit.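

Going by these compounds alone, compound 2 and compound 3 each give only a limit of the assay, not a number, and no step between them can be read. The compounds shown leave open whether trifluoromethoxy in place of chloro changes the read-out at all; none of them has an exact value.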